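The compounds below may be only part of what the source reports. "The series", "measured", "known", "first", "only" and "open" are said of these compounds alone.

Working notes on the series. Three compounds have been run in a functional assay on the whole organism for inhibition, with Mythimna separata as the target, with a stated time of 5 days; a higher number here means that more compound is needed for the effect, a lower number that less compound is needed. Compound 1 `CC(C)(C)n1ncc(OCc2nnc(-c3ccc(Cl)cc3Cl)s2)c(Cl)c1=O` gives 62200 nM in this assay. Compound 3 `CC(C)(C)n1ncc(OCc2nnc(-c3c(F)c(F)c(F)c(F)c3F)o2)c(Cl)c1=O` gives 271000 nM in this assay. For compound 2 `CCn1ncc(OCc2nnc(-c3ccccc3)o2)c(Cl)c1=O` the result in this assay is > 299000 nM, a limit of the assay and not a number. One of the three values shown is therefore (the limit of > 299000 nM in this assay, at which 1 of the 3 values shown sits).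

Among the two numbers, compound 1 stands lowest; compound 3 gives the higher number, and the gap between them lies beyond the scatter. Among the measured compounds shown here, no pair of measured compounds differs in a single place, so no measured step is available to lean on.

Compound 4 `Cc1cc(C)cc(-c2nnc(COc3cnn(C(C)(C)C)c(=O)c3Cl)s2)c1` is not yet measured. It differs from compound 1 by 3,5-dimethylphenyl in place of 2,4-dichlorophenyl on an aromatic carbon, the change sitting on an aromatic carbon of the five-membered aromatic ring with two nitrogens and one sulfur, next to the ring nitrogen and next to the ring sulfur. With no measured step of this kind in the set, the expectation is a step in this assay that does not go beyond the scatter, if anything toward a somewhat higher number. The expected step is a 1.4-fold higher number from compound 1 to compound 4 (0.16 log units; within the scatter). Compound 4 is estimated at 90000 nM in this assay, with a range from 25000 nM to 300000 nM.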

Compound 4, half-maximal effective concentration: > 299000 nM
Compound 4: no number, only a limit; the forecaster's own chance of this, stated with the estimate: 20%; middle value at least 3.3-fold (0.52 log units) from the limit.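

In this assay, the set now has one measured step on an aromatic carbon of the five-membered aromatic ring with 2 nitrogen and 1 sulfur: 3,5-dimethylphenyl in place of 2,4-dichlorophenyl gives an at least 4.8-fold higher number from compound 1 to compound 4 (0.68 log units; beyond the scatter). Compound 4 gives > 299000 nM, a limit of the assay and not a number, so the step has a lower bound but no upper one. The result at this position is therefore not indifferent to the change, even though both groups have 8 heavy atoms and one six-membered aromatic ring of carbon only, and the top of the range is filling: the limit of > 299000 nM in this assay, at which 2 of the 4 values shown sit.

The change replaces chlorine with methyl and alters the substitution pattern on the phenyl ring at once, so the compounds shown do not separate these two parts of the step. Also open, on these data alone, is how a phenyl ring carrying a nitrile or a methoxy group at this position would read in this assay, and whether any such group would give a lower number than compound 1 does.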